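Pyridin-3-yl Out, (Ethylsulfonyl)amino In: an Expected Response

A few compounds are considered here, and "the series" means these few. Any claim that something is new, unique, unknown or untested is made for them only; others in the source may bear on it.

Compound 1, `COc1cccc2c1CCC2c1ncc[nH]1`, in a functional assay on CHO cells for agonist activity at Alpha-1A adrenergic receptor (Homo sapiens), read by FLIPR and calcium flux; on this read-out higher numbers stand for larger maximal responses and lower numbers for smaller maximal responses: 65%
Compound 2, `c1cncc(-c2cccc3c2CCC3c2ncc[nH]2)c1`, in this assay: 36%

Going by the values given here, compound 2 stands lowest of the two numbers; its nearest neighbour is compound 1, and the single measured step is a number 29 percentage points lower from compound 1 to compound 2 (beyond the scatter). Compound 3 `CCS(=O)(=O)Nc1cccc2c1CCC2c1ncc[nH]1` differs from compound 2 by (ethylsulfonyl)amino in place of pyridin-3-yl on an aromatic carbon. Among the compounds with values here, no measured step pairs the entering group with anything, so the step from compound 1 to compound 2 bears on it only in that the group whose arrival accompanied that drop now departs. Compound 3 is therefore expected to recover part of that loss, an estimated a number 19 percentage points higher from compound 2 to compound 3 (beyond the scatter) in this assay. The estimate for compound 3 is 55%, with a range from 30% to 85%.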

Compound 3, largest response reached (Emax), in percent of the reference or control that the assay uses: 86%
The estimate for compound 3 lay 31 percentage points below the measured number, outside the stated range (above it).
By their numbers in this assay, from the lowest: compound 2; then compound 1; then compound 3.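

In this assay, the (ethylsulfonyl)amino group on this aromatic carbon gives a number 50 percentage points higher from compound 2 to compound 3 (beyond the scatter), so a group with no ring can carry a far larger response here than pyridin-3-yl. It also surpasses methoxy, with a number 21 percentage points higher from compound 1 to compound 3 (beyond the scatter), so the change is more than a return to the level of the methoxy compound. Nothing available explains this rise.

The compounds shown leave open whether the response depends on the ethyl chain or on the sulfonyl group. They also leave open how a methylsulfonylamino group, a longer propylsulfonylamino chain or a plain amine would compare at this carbon.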